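The source may report more compounds than this note shows. Statements on the series, on what has been measured and on what is new or still open speak of the compounds shown alone.

Measured so far:
compound 1, `CC1(Cc2ccccc2)CC(S(=O)(=O)c2ccccc2)=C(c2ccc(/C(N)=N/O)cc2)O1`, with 94600 nM;
compound 2, `CC1(Cc2ccccc2)CC(S(=O)(=O)c2ccc(/C(N)=N/O)cc2)=C(c2ccc(Nc3ccccc3/C(N)=N/O)cc2)O1`, with 48100 nM.

In an ADME assay on THP-1 cells (Homo sapiens) for cytotoxicity, read by flow cytometry, with a stated time of 72 h (a higher number here means a weaker inhibitor, a lower number a stronger inhibitor), compound 1 gives 94600 nM, and compound 2 gives 48100 nM. The two values lie within the usual scatter of each other, so on the numbers shown compound 1 cannot be set apart from compound 2; both sit at very high concentrations, which marks them as weak in this assay.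

Compound 3, `CC1(Cc2ccccc2)CC(S(=O)(=O)c2ccc(/C=C/c3ccc(/C(N)=N/O)cc3)cc2)=C(c2ccc(/C(N)=N/O)cc2)O1`, has not yet been measured. It differs from compound 1 in one place: a group of 12 heavy atoms (9 carbon, 2 nitrogen, 1 oxygen; one six-membered aromatic ring of carbon only) in place of a hydrogen atom, on an aromatic carbon. Put simply, a larger group containing one six-membered aromatic ring of carbon only takes the place of a hydrogen atom, on an aromatic carbon.

Among the compounds with values here, no step between measured compounds is available to guide the size of this change. With compound 2, which also carries two amidoxime groups, giving 48100 nM, the expected step of a 1.7-fold lower number from compound 1 to compound 3 (0.24 log units; within the scatter) is small, toward a lower number, and not clearly beyond the scatter. Compound 3 is therefore estimated at 55000 nM, with a range from 20000 nM to 150000 nM.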

Compound 3, half-maximal inhibitory concentration: > 50000 nM
Compound 3 gave a limit, no number; the forecaster's own chance of this, stated with the estimate: 20%; the middle value does not contradict the limit.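

In this assay compound 3 gives > 50000 nM, which is a limit and not a number. Within the data shown here, no step from compound 1 to compound 3 can be read from this result. The compounds shown leave open whether the larger group in place of a hydrogen atom, on an aromatic carbon, changes the value in this assay at all.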